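Para-methyl Step Carried From One Core to Another

The compounds below may be only part of what the source reports. "The series", "measured", "known", "first", "only" and "open" are said of these compounds alone.

The study concerns four compounds tested in an assay on isolated protein for inhibition of Amine oxidase [flavin-containing] A (Homo sapiens), read by fluorescence and spectrophotometry, with a stated time of 20 min; on this read-out higher numbers stand for weaker inhibition and lower numbers for stronger inhibition. Compound 1 `N#Cc1cc2cc(-c3ccccc3)n(O)c2cc1C#N` gives 6920 nM, while compound 2 `Cc1ccc(-c2cc3cc(C#N)c(C#N)cc3n2O)cc1` gives 1140 nM; the change between them, (methyl in place of hydrogen on an aromatic carbon), yields a 6.1-fold lower number from compound 1 to compound 2 (0.78 log units; beyond the scatter). Compound 3 `COn1c(-c2ccccc2)c(CO)c2cc(C#N)c(C#N)cc21` rests on a different core; how its core differs from that of compound 1 is not broken down here. In this assay compound 3 gives 4990 nM. Compound 4 `COn1c(-c2ccc(C)cc2)c(CO)c2cc(C#N)c(C#N)cc21` is the unmeasured partner of compound 3, and the change, (methyl in place of hydrogen on an aromatic carbon), is the same one seen from compound 1 to compound 2. Because that earlier step was a 6.1-fold lower number from compound 1 to compound 2 (0.78 log units; beyond the scatter), a step of similar direction, though somewhat smaller, is expected, namely a 3.6-fold lower number from compound 3 to compound 4 (0.55 log units; beyond the scatter). Compound 4 is therefore estimated at 1400 nM, with a likely range from 500 nM to 4500 nM.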

Compound 4, half-maximal inhibitory concentration: 5120 nM
For compound 4 the middle estimate is 3.7-fold (0.56 log units) below the measured one, outside the stated range (above it).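

In this assay the change from phenyl to 4-methylphenyl gave a 1.0-fold higher number from compound 3 to compound 4 (0.01 log units; within the scatter), so the stronger inhibition seen with this change on the core of compound 1 did not appear on the core of compound 3. The change therefore did not carry over from one core to the other: the same change on two cores in this assay, a 6.1-fold lower number (0.78 log units; beyond the scatter) from compound 1 to compound 2 and a 1.0-fold higher number (0.01 log units; within the scatter) from compound 3 to compound 4, 6.2-fold (0.79 log units) apart, beyond the scatter of two such steps. This rests on a single pair for each core, and it does not show which feature of the two cores accounts for the gap.

The compounds shown leave open how an ethyl group, an amine or a carboxylic acid in place of the methyl would fare on either core. They also leave open how the methyl step would read on a third core.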